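The compounds below may be only part of what the source reports. "The series", "measured", "known", "first", "only" and "open" are said of these compounds alone.

Series of three measured analogues on one shared core, differing only in the chain carried by the carbonyl carbon: compound 1 `Cc1cn(C2CC(N=[N+]=[N-])C(COC(=O)NCCCC(=O)O)O2)c(=O)[nH]c1=O`, compound 2 `Cc1cn(C2CC(N=[N+]=[N-])C(COC(=O)CCCN)O2)c(=O)[nH]c1=O` and compound 3 `Cc1cn(C2CC(N=[N+]=[N-])C(COC(=O)NCCCO)O2)c(=O)[nH]c1=O`. In a functional assay on MT4 cells (Homo sapiens) for cytotoxicity (on this read-out lower numbers stand for higher toxicity in this test and higher numbers for lower toxicity in this test), compound 1 gives > 50000 nM, a limit of the test and not a number. Compound 2 likewise reaches only a limit in this assay, > 50000 nM. Compound 3 also stands at a limit in this assay, > 50000 nM. Of compound 3 nothing beyond this limit is known, and the two other values shown are limits as well. The three steps between these compounds therefore cannot be read: a step that the two limits leave unreadable from compound 1 to compound 2, a step that the two limits leave unreadable from compound 1 to compound 3 and a step that the two limits leave unreadable from compound 2 to compound 3. All three values sit together at the limit of > 50000 nM in this assay, at which 3 of the 3 values shown sit.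

Compound 4 `Cc1cn(C2CC(N=[N+]=[N-])C(COC(=O)NCCCC(=O)OC(C)(C)C)O2)c(=O)[nH]c1=O` is not yet measured. It differs from compound 3 by tert-butoxycarbonyl in place of hydroxy on a saturated chain carbon, three bonds along the chain from an amide-type nitrogen. Among the compounds with values here, the steps that bear on this change are the unreadable ones above; none of them gives a size. With every neighbouring value at the same limit, no step beyond the scatter is expected for a number no higher from compound 3 to compound 4 (the limit leaves the size open) in this assay. Compound 4 is estimated at 50000 nM, with a range from 20000 nM to 100000 nM, and the test is expected most likely to report again only a limit.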

Compound 4, half-maximal cytotoxic concentration in the MT4 assay: > 50000 nM
Compound 4: a limit, no number; the forecaster's own chance of this, stated with the estimate: 85%; the middle value sits exactly at the limit.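

Within the data shown here, in the MT4 assay compound 4 also stands only at a limit, so its steps from compound 1 and compound 3 cannot be read and no new step follows. In a physicochemical assay for lipophilicity (on this read-out higher numbers stand for higher lipophilicity and lower numbers for lower lipophilicity), compound 3 gives -1.24 and compound 4 gives 0.88. The compounds shown leave open how far any of the four lies from that limit in the MT4 assay.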